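Swapping acetyl for trifluoromethyl in a cell toxicity test

A few compounds are considered here, and "the series" means these few. Any claim that something is new, unique, unknown or untested is made for them only; others in the source may bear on it.

Compound 1 `CC(=O)c1ccc(NC(=O)Nc2cc(C)nc3ccccc23)cc1` gives 19000 nM
Compound 2 `Cc1cc(NC(=O)Nc2ccc(F)c(F)c2)c2ccccc2n1` gives 21000 nM

Both compounds were measured in an ADME assay on HepG2 cells (Homo sapiens) for cytotoxicity, with a stated time of 72 h; a lower number here means that less compound is needed, a higher number that more compound is needed for the effect. Compound 1, at 19000 nM, stands level with compound 2, at 21000 nM, since the two values lie within the scatter of each other. Neither compound can be said to stand apart from the other.

Compound 3 `Cc1cc(NC(=O)Nc2ccc(C(F)(F)F)cc2)c2ccccc2n1` has not yet been measured. It carries trifluoromethyl in place of acetyl on an aromatic carbon, and the rest of compound 1 stays the same: trifluoromethyl in place of acetyl on an aromatic carbon. The change sits on a six-membered aromatic ring of carbon only, para to a large group.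

Among the measured compounds shown here, no two measured compounds differ in just one place, so the data offer no direct guide to this swap. The expectation is therefore cautious, with no shift beyond the scatter. The expected step of a 1.3-fold lower number from compound 1 to compound 3 (0.10 log units; within the scatter) is only an estimate. In this assay, the estimate for compound 3 is 15000 nM, with an expected range from 6000 nM to 35000 nM.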

Compound 3, half-maximal effective concentration: 23000 nM
Compound 3: middle estimate off by 1.5-fold (0.19 log units), on the low side; the range from low to high includes it.
By their numbers in this assay, from the lowest: compounds 1, 2 and 3 (each within the scatter of the next).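

In this assay the swap of acetyl for trifluoromethyl on this aromatic carbon gives a 1.2-fold higher number from compound 1 to compound 3 (0.08 log units; within the scatter) and so leaves the two compounds level. Among the compounds shown here, this is the first comparison in the set between compounds that differ in only one place, and it shows that at this position, the one para to a large group, a group with a carbonyl and one hydrogen-bond acceptor and a group with no hydrogen-bond acceptor cannot be told apart in this test. Nothing measured here offers an explanation for this result.

As far as these compounds go, one swap between two groups says little about the position as a whole, so it remains open whether an amine, a carboxylic acid or a longer chain on the same aromatic carbon would also stay within the scatter of compound 1 or would give a clear step. From the compounds shown here alone, it also remains open whether the same swap of acetyl for trifluoromethyl would give so small a step on a different core or in a different test.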